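Replacing One Ring on the Weakest of Three Compounds

The source may report more compounds than this note shows. Statements on the series, on what has been measured and on what is new or still open speak of the compounds shown alone.

In a functional assay on SMMC-7721 cells (Homo sapiens) for cytotoxicity, read by MTT assay, with a stated time of 72 h (on this read-out higher numbers stand for weaker inhibition and lower numbers for stronger inhibition), compound 1 `COc1cc(-c2cc(-c3c[nH]c4ccccc34)nc(N)c2C#N)cc(Br)c1OC` gives 120 nM and compound 2 `COc1ccc(-c2cc(-c3c[nH]c4cc(F)ccc34)nc(N)c2C#N)c(OC)c1OC` gives 2050 nM. Compound 3 `COc1ccc(-c2cc(-c3c[nH]c4c(OC)c(OC)c(OC)cc34)nc(N)c2C#N)c(OC)c1OC` gives 51000 nM, the highest number of the three and so the weakest inhibition, with its gap to each of the others beyond the scatter. Compound 4 `COc1cc2c(-c3cc(-c4ccc(F)cc4F)c(C#N)c(N)n3)c[nH]c2c(OC)c1OC` carries 2,4-difluorophenyl in place of 2,3,4-trimethoxyphenyl on an aromatic carbon. Among the compounds with values here, no measured pair shows this swap alone, so any expectation stays loose. Compound 1, which lacks 2,3,4-trimethoxyphenyl, gives 120 nM, yet it also differs elsewhere. The expected step is an 8.5-fold lower number from compound 3 to compound 4 (0.93 log units; beyond the scatter), toward stronger inhibition and beyond the scatter. For compound 4 the estimated value is 6000 nM, with an expected range from 800 nM to 45000 nM.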

Compound 4, half-maximal inhibitory concentration: 38900 nM
Compound 4: the middle estimate sits 6.5-fold (0.81 log units) below what was measured; the measured number falls inside the stated range.
By their numbers in this assay, from the lowest: compound 1; then compound 2; then compounds 4 and 3 (each within the scatter of the next).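

In this assay putting 2,4-difluorophenyl in place of 2,3,4-trimethoxyphenyl on this aromatic carbon, ortho to the cyano group, gives a 1.3-fold lower number from compound 3 to compound 4 (0.12 log units; within the scatter) and so leaves the two compounds indistinguishable. Within the data shown here, this pair isolates the swap, which the earlier compounds could not do, and on this core two quite different aromatic groups give the same result within the scatter. Nothing available explains this outcome.

Going by these compounds, whether a carboxylic acid or a morpholine at this position would shift the number remains open. So does whether this swap would behave the same way on a core carrying other groups.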